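This account rests on a few compounds, and the source may have more. Where it says the series, first, only, none or still open, it means among the compounds named here.

Measured in a functional assay on MCF7 cells (Homo sapiens) for inhibition, with a stated time of 72 h; a lower number here means a stronger inhibitor, a higher number a weaker inhibitor:
- compound 1 `COc1ccccc1-c1ccc(CNc2nc(NC3CCC(N)CC3)nc3c2ncn3C2CCCC2)cc1`: 303 nM
- compound 2 `NC1CCC(Nc2nc(NCc3ccc(-c4ccco4)cc3)c3ncn(C4CCCC4)c3n2)CC1`: 85 nM

Compound 2 holds the lower of the two numbers in this assay, at 85 nM. Compound 3 `NC1CCC(Nc2nc(NCc3ccc(-c4ccsc4)cc3)c3ncn(C4CCCC4)c3n2)CC1` has not yet been measured. It keeps everything in compound 2 except one aromatic ring: thiophen-3-yl in place of furan-2-yl on an aromatic carbon. Thiophen-3-yl stands in place of furan-2-yl on an aromatic carbon, para to a large group.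

Among the measured compounds shown here, only one measured step bears on this change: a 3.6-fold lower number from compound 1 to compound 2 (0.55 log units; beyond the scatter). This modest step changed the same substituent, with furan-2-yl in place of 2-methoxyphenyl. It shows that the number responds to this substituent, but it swapped a six-membered ring for a five-membered one. For the measured compounds named here, the new change swaps one five-membered aromatic ring for another, and no measured compound carries thiophen-3-yl, so the direction is poorly defined. A change smaller than a 3.6-fold lower number from compound 1 to compound 2 (0.55 log units; beyond the scatter) is expected, with a slight lean towards a higher number. The expected step is a 1.2-fold higher number from compound 2 to compound 3 (0.07 log units; within the scatter), which is not expected to lie beyond the scatter. For compound 3 the estimated value is 100 nM, with an expected range of 40 nM to 250 nM.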

Compound 3, half-maximal inhibitory concentration: 145 nM
For compound 3 the middle estimate is 1.5-fold (0.16 log units) below the measured one, within the range that was stated.
By their numbers in this assay, from the lowest: compounds 2 and 3 (each within the scatter of the next); then compound 1.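

In this assay the replacement of furan-2-yl by thiophen-3-yl on the aromatic carbon para to a large group gives a 1.7-fold higher number from compound 2 to compound 3 (0.23 log units; within the scatter), so these two five-membered aromatic rings, each with one hetero atom, are not told apart at this position. Compound 3 also shows a 2.1-fold lower number from compound 1 to compound 3 (0.32 log units; beyond the scatter), which means that a second five-membered ring, not furan-2-yl alone as in a 3.6-fold lower number from compound 1 to compound 2 (0.55 log units; beyond the scatter), now stands apart from the 2-methoxyphenyl of compound 1, and none of the three compounds goes against this. The series carries no measured property of these groups that could account for either step, so the numbers stand here without an explanation.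

The change from furan-2-yl to thiophen-3-yl alters both the hetero atom and the point of attachment, and only thiophen-2-yl or furan-3-yl at the same place could separate the two. Also open, from the compounds shown here alone, is how this position responds to groups of a different kind, such as an unsubstituted phenyl, a carboxylic acid or an aminomethyl group, since all three compounds carry an aromatic ring there.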